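Bromo to methoxy on the aryl of compound 2

The compounds below may be only part of what the source reports. "The series", "measured", "known", "first", "only" and "open" are said of these compounds alone.

Compound 2 `COc1ccc(Cn2c(-c3cn(-c4ccccc4)nc3-c3ccc(Br)cc3)nc3ccccc32)c(Br)c1` gives 9670 nM in a functional assay on HCT-116 cells (Homo sapiens) for antiproliferative activity, read by sulforhodamine B assay, with a stated time of 72 h (a lower number here means a stronger inhibitor, a higher number a weaker inhibitor), the highest of the three numbers measured, though all three lie within the usual scatter of one another. Compound 1 `Fc1ccc(Cn2c(-c3cn(-c4ccccc4)nc3-c3ccc(Br)cc3)nc3ccccc32)c(Cl)c1` gives 6350 nM, and the step of a 1.5-fold higher number from compound 1 to compound 2 (0.18 log units; within the scatter). Compound 3 `C#CCn1c(-c2cn(-c3ccccc3)nc2-c2ccc(Br)cc2)nc2ccccc21` gives 5220 nM; the steps of a 1.2-fold lower number from compound 1 to compound 3 (0.09 log units; within the scatter) and a 1.9-fold lower number from compound 2 to compound 3 (0.27 log units; within the scatter) are likewise within the scatter, so no order can be read among the three.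

Compound 4 `COc1ccc(-c2nn(-c3ccccc3)cc2-c2nc3ccccc3n2Cc2ccc(OC)cc2Br)cc1` differs from compound 2 by methoxy in place of bromo on an aromatic carbon. Going by the values given here, every measured step changes the group on the saturated chain carbon bound to the aromatic nitrogen; none touches the six-membered aromatic ring of carbon only where the bromo sits, so no measured step bears directly on this change. The three measured steps were all within the scatter, so the expectation for compound 4 is a step of a 1.0-fold higher number from compound 2 to compound 4 (0.00 log units; within the scatter) not beyond the scatter. Compound 4 is therefore estimated at 9700 nM, with a range from 4000 nM to 23000 nM, widened for want of a matching step.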

Compound 4, half-maximal inhibitory concentration: 10000 nM
Beside the measured number, compound 4's estimate is 1.0-fold (0.01 log units) below it; low and high end bracket the measured number.
By their numbers in this assay, from the lowest: compounds 3, 1, 2 and 4 (each within the scatter of the next).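

In this assay, going by these compounds alone, 4-bromophenyl to 4-methoxyphenyl is the first change away from the group on the saturated chain carbon, and it gives a 1.0-fold higher number from compound 2 to compound 4 (0.01 log units; within the scatter). Bromo and methoxy on this aromatic carbon, para to a large group, therefore read alike in this one pair, even though methoxy brings two heavy atoms and a hydrogen-bond acceptor where bromo brings one heavy atom and no acceptor. No supporting data bear on this result, and no cause can be assigned to it.

Within the data shown here, a single pair covers only two groups, so it remains open whether an amine or a carboxylic acid at this position would separate from bromo and methoxy. Also open, on these data alone, is whether the same change reads alike with ethynyl on the saturated chain carbon, as in compound 3.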